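The source may report more compounds than this note shows. Statements on the series, on what has been measured and on what is new or still open speak of the compounds shown alone.

Measured so far:
compound 1 `COc1cc(OC)cc(-c2nnc(SCC(=O)c3ccccc3)o2)c1` (170 nM)
compound 2 `COc1ccc(-c2nnc(SCC(=O)c3ccccc3)o2)c(O)c1` (280 nM)
compound 3 `O=C(CSc1nnc(-c2ccncc2)o1)c1ccc(Br)cc1` (4230 nM)

These numbers all come from a functional assay on MCF7 cells (Homo sapiens) for cytotoxicity, read by MTT assay and propidium iodide staining, with a stated time of 24 h (on this read-out lower numbers stand for stronger inhibition and higher numbers for weaker inhibition), and are the only data available so far. Compound 1 (170 nM) lies within the usual scatter of compound 2 (280 nM), so this pair cannot be separated here. Compound 3 (4230 nM) has a much higher number, well beyond the scatter from compound 1, and that means much weaker inhibition.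

The next compound is compound 4 `COc1cc(OC)cc(-c2nnc(SCC(=O)c3ccc(Br)cc3)o2)c1` which keeps the core of compound 1 and changes one place, phenyl to 4-bromophenyl (bromo in place of hydrogen on an aromatic carbon). Among the measured compounds shown here, no two measured compounds differ in only one place, so no measured step shows what this change does. Compound 3 (4230 nM) also carries the 4-bromophenyl, but it differs from compound 1 elsewhere too, which makes it only a weak hint towards a higher number.

The expected step of a 1.5-fold higher number from compound 1 to compound 4 (0.17 log units; within the scatter) is small and should stay within the scatter. For compound 4 the estimated value is 250 nM with an expected range from 70 nM to 900 nM in this assay.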

Compound 4, half-maximal inhibitory concentration: 270 nM
Beside the measured number, compound 4's estimate is 1.1-fold (0.03 log units) below it; the measured number falls inside the stated range.
By their numbers in this assay, from the lowest: compounds 1, 4 and 2 (each within the scatter of the next); then compound 3.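

Among the compounds shown here, this is the first pair in the set that differs in only one place, so it is the first direct look at this change. In this assay, putting a bromo in place of hydrogen on the phenyl ring gives a 1.6-fold higher number from compound 1 to compound 4 (0.20 log units; within the scatter), so the two compounds cannot be told apart, and on the core of compound 1 this aromatic carbon, para to a large group, can carry a bromine atom without a change that stands clear of the scatter. Nothing measured here offers a reason for this outcome, and a single pair on a single core sets no general rule for the 4-bromophenyl group.

The compounds shown leave open whether this same position would give a similar result with a very different group, such as an amine, a carboxylic acid or a longer chain, since bromo is the only replacement for hydrogen seen here. For the compounds shown here, they also leave open whether the same swap would give a similarly small step on a different core, because no other pair with this change can be read.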